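Adding a cyclopropyl to the pyridine of compound 2

The compounds below may be only part of what the source reports. "The series", "measured", "known", "first", "only" and "open" are said of these compounds alone.

Compound 1 `C[C@H](NC(=O)c1cc(C(F)(F)F)nn1C)c1nc(-c2ccccn2)no1`: > 30000 nM
Compound 2 `C[C@H](NC(=O)c1cc(C(F)(F)F)nn1C)c1nc(-c2ccncc2)no1`: 5250 nM

Among the measured compounds shown here, in an assay on T-REx-293 cells for inhibition of potassium channel subfamily T member 1 (Homo sapiens), read by patch clamp (on this read-out higher numbers stand for weaker inhibition and lower numbers for stronger inhibition), compound 2 gives 5250 nM, the only plain number among the values shown. Compound 1 gives > 30000 nM, which is a limit of the assay rather than a number (the limit of > 30000 nM in this assay, at which 1 of the 2 values shown sits). For the measured compounds named here, the single measured step, an at least 5.7-fold lower number from compound 1 to compound 2 (0.75 log units; beyond the scatter), shows that changing the ring attached to the shared core can move the number well beyond the scatter.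

Compound 3 `C[C@H](NC(=O)c1cc(C(F)(F)F)nn1C)c1nc(-c2ccnc(C3CC3)c2)no1` keeps the pyridin-4-yl of compound 2 and differs from it in one place: cyclopropyl in place of hydrogen on an aromatic carbon. Going by the values given here, no measured step adds a group to this ring, so the earlier step is only indirect guidance, and the expected step of a 1.8-fold lower number from compound 2 to compound 3 (0.24 log units; within the scatter) is small, in either direction or none beyond the scatter. Compound 3 is therefore expected to give about 3000 nM, within a range from 700 nM to 15000 nM.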

Compound 3, half-maximal inhibitory concentration: 16 nM
For compound 3 the middle estimate is 190-fold (2.27 log units) above the measured one; the measured number lies below the stated range.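

In this assay, adding one group to the ring, a cyclopropyl on an aromatic carbon next to the ring nitrogen, gives a 330-fold lower number from compound 2 to compound 3 (2.52 log units; beyond the scatter), so this position can change the inhibition strongly, which the earlier swap of pyridin-2-yl for pyridin-4-yl could not reveal. The full change from pyridin-2-yl to 2-cyclopropylpyridin-4-yl amounts to an at least 1800-fold lower number from compound 1 to compound 3 (3.27 log units; beyond the scatter). That step starts from a limit of the assay, not from a number: the limit of > 30000 nM in this assay, at which 1 of the 3 values shown sits.

On these data alone, what a methyl, an isopropyl or an amine would do at this position stays open, and with it whether the three-membered ring itself matters or any carbon group of similar size would serve. Also open, as far as these compounds go, is whether a cyclopropyl would act in the same way on the pyridin-2-yl of compound 1.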